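The source may hold more compounds than are shown below. What is called first, only, known or untested is meant among the compounds shown, and "the series" means these compounds.

For the measured compounds named here, in a functional assay on NCI-H460 cells (Homo sapiens) (a lower number here means that less compound is needed, a higher number that more compound is needed for the effect), only two compounds have numbers so far. Compound 1 `COc1cc(C2OC(c3ccc(N(C)C)cc3)=NN2C(C)=O)cc(OC)c1OC` gives 0.044 uM, and compound 2 `COc1cc(C2OC(c3ccccc3N(C)C)=NN2C(C)=O)cc(OC)c1OC` gives 109 uM, the higher of the two numbers by a margin well beyond the scatter.

Compound 3 `COc1cc(C2OC(c3cccc(N(C)C)c3)=NN2C(C)=O)cc(OC)c1OC` keeps the shared core and changes only the attachment of the dimethylamino group on the phenyl ring: 3-(dimethylamino)phenyl in place of 2-(dimethylamino)phenyl on a carbon with a double bond to nitrogen. The two compounds have the same atoms, joined differently.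

Going by the values given here, one measured step bears on this change: a 2500-fold higher number from compound 1 to compound 2 (3.39 log units; beyond the scatter). This large step comes from 2-(dimethylamino)phenyl replacing 4-(dimethylamino)phenyl at the same place, so the attachment of this group can matter greatly in this series. Compound 3 carries the group of neither measured compound, and one step cannot fix its number. A number between compound 1 at 0.044 uM and compound 2 at 109 uM is the working expectation, with wide uncertainty.

The expected change is a 55-fold lower number from compound 2 to compound 3 (1.74 log units; beyond the scatter), a large step to a lower number. For compound 3 the estimated value is 2 uM, with an expected range from 0.15 uM to 30 uM.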

Compound 3, concentration for half-maximal effect: 0.26 uM
Beside the measured number, compound 3's estimate is 7.7-fold (0.89 log units) above it; the range from low to high includes it.
By their numbers in this assay, from the lowest: compound 1; then compound 3; then compound 2.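

In this assay, the step of a 420-fold lower number from compound 2 to compound 3 (2.62 log units; beyond the scatter) shows that the very high number of compound 2 does not extend to every shift of the dimethylamino group away from 4-(dimethylamino)phenyl: 3-(dimethylamino)phenyl keeps most of the effect, and the large loss is specific to 2-(dimethylamino)phenyl among the three attachments shown. The remaining step, a 5.9-fold higher number from compound 1 to compound 3 (0.77 log units; beyond the scatter), is modest but beyond the scatter, so the attachment still matters between these two groups, and the numbers now rise in the order 4-(dimethylamino)phenyl, 3-(dimethylamino)phenyl, 2-(dimethylamino)phenyl on this carbon with a double bond to nitrogen. Nothing available accounts for this order or for the unequal sizes of the two steps.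

Going by these compounds, all three compounds carry the same dimethylamino group, so it remains open whether a primary amine, a methoxy group or a carboxylic acid on the phenyl ring would follow the same order across the three attachments. The acetyl group also stays constant throughout, leaving open how a longer acyl chain at that ring nitrogen would change these numbers.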